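What removing one methyl may do to compound 3

The source may report more compounds than this note shows. Statements on the series, on what has been measured and on what is new or still open speak of the compounds shown alone.

compound 1 `Nc1sc(-c2ccc(Cl)cc2)c(-c2ccc(Cl)cc2)c1C(=O)N1CCCCC1` gives 4620 nM
compound 2 `CC1CN(C(=O)c2c(N)sc(-c3ccc(Cl)cc3)c2-c2ccc(Cl)cc2)CCN1` gives 4930 nM
compound 3 `CN1CCN(C(=O)c2c(N)sc(-c3ccc(Cl)cc3)c2-c2ccc(Cl)cc2)CC1` gives 590 nM

All three values come from a functional assay on A549 cells (Homo sapiens) for inhibition, read by sulforhodamine B assay, with a stated time of 72 h (on this read-out higher numbers stand for weaker inhibition and lower numbers for stronger inhibition), and compound 3 has the lowest number of the three, making it the strongest inhibitor of this small set. Compound 4 `Nc1sc(-c2ccc(Cl)cc2)c(-c2ccc(Cl)cc2)c1C(=O)N1CCNCC1` differs from compound 3 by a single change: hydrogen in place of methyl on an amine nitrogen in a ring with hydrogen in place of methyl on an amine nitrogen in a ring. For the measured compounds named here, two measured steps bear on this. The closest is an 8.4-fold lower number from compound 2 to compound 3 (0.92 log units; beyond the scatter) with 4-methylpiperazin-1-yl replacing 3-methylpiperazin-1-yl, and compound 2 resembles compound 4 in carrying hydrogen on an amine nitrogen in a ring. The other is a 7.8-fold lower number from compound 1 to compound 3 (0.89 log units; beyond the scatter) and it is of similar size. Neither step isolates this exact change, so only part of that gap is expected to reappear. The expected result in this assay is a 3.7-fold higher number from compound 3 to compound 4 (0.57 log units; beyond the scatter) as an estimate, pointing toward weaker inhibition. Compound 4 is estimated at 2200 nM with an expected range of 600 nM to 7000 nM for now.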

Compound 4, half-maximal inhibitory concentration: 1020 nM
The estimate for compound 4 lay 2.2-fold (0.33 log units) above the measured number; measured number inside the range.
By their numbers in this assay, from the lowest: compounds 3 and 4 (each within the scatter of the next); then compounds 1 and 2 (each within the scatter of the next).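

In this assay, the methyl on the amine nitrogen of compound 3 proves dispensable, since a 1.7-fold higher number from compound 3 to compound 4 (0.24 log units; within the scatter) does not stand out from the usual scatter. Compound 4 also separates the effect of the ring nitrogen from that of the methyl on it: with no methyl at that position, the swap of piperidin-1-yl for piperazin-1-yl alone still gives a 4.5-fold lower number from compound 1 to compound 4 (0.66 log units; beyond the scatter). A methyl on a saturated ring carbon is a different matter, as removing it gives a 4.8-fold lower number from compound 2 to compound 4 (0.68 log units; beyond the scatter), so within these compounds the place of the methyl on the piperazine ring matters more than its presence on the amine nitrogen.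

On these data alone, how a longer chain such as ethyl, or an acetyl group, on this amine nitrogen would read remains open. Nothing measured here offers an explanation for any of these differences.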